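Cap Group Variation in Hydroxamate-Based Antiproliferative Agents

The source may report more compounds than this note shows. Statements on the series, on what has been measured and on what is new or still open speak of the compounds shown alone.

Measured compounds:
compound 1, `O=C(CCCCC[C@H](NC(=O)c1ccc(Br)cc1)C(=O)Nc1ccc(-c2ccccc2)cc1)NO`, 335 nM
compound 2, `CN(C)c1ccc(C(=O)N[C@@H](CCCCCC(=O)NO)C(=O)Nc2cccc3cccnc23)cc1`, 148 nM

Of the compounds shown here, two have been tested in a functional assay on A549 cells (Homo sapiens) for antiproliferative activity; a higher number here means a weaker inhibitor, a lower number a stronger inhibitor. Compound 1 gives 335 nM, and compound 2 gives 148 nM. Compound 2 therefore has the lower of the two numbers, with compound 1 standing a step above it that lies beyond the usual scatter. The two compounds differ in more than one place, so nothing can be said about which of those differences carries the gap.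

Compound 3, `O=C(/C=C/c1ccccc1)N[C@@H](CCCCCC(=O)NO)C(=O)Nc1cccc2cccnc12`, is built on the core of compound 2 and differs from it in a single place: 2-phenylethenyl in place of 4-(dimethylamino)phenyl on a carbonyl carbon. For the measured compounds named here, no pair of measured compounds shows the effect of this kind of cap exchange, so there is no precedent to lean on. The expectation is a change in this assay that is small, most likely a modest move toward a higher number, or none beyond the scatter. The estimated step of a 1.4-fold higher number from compound 2 to compound 3 (0.13 log units; within the scatter) reflects that. Compound 3 is accordingly expected to give about 200 nM, within a range from 80 nM to 500 nM.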

Compound 3, half-maximal inhibitory concentration: 73 nM
Compound 3: middle estimate off by 2.7-fold (0.44 log units), on the high side; measured number below the stated range.
By their numbers in this assay, from the lowest: compound 3; then compound 2; then compound 1.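

Exchanging 4-(dimethylamino)phenyl for 2-phenylethenyl on a carbonyl carbon gives, in this assay, a 2.0-fold lower number from compound 2 to compound 3 (0.31 log units; beyond the scatter), and this is the only single-place comparison among the compounds shown. It shows what the gap between compound 1 and compound 2 could not: with the rest of the core held fixed, the number in this assay responds to the group at this position, and here it moves toward a stronger inhibitor. A six-membered aromatic ring of carbon only stands on both sides of the exchange, so the step goes with the loss of the nitrogen and its hydrogen-bond acceptor, the gain of a double bond outside aromatic rings, or both together.

On these data alone, an unsubstituted phenyl or a saturated 2-phenylethyl group on the same carbonyl carbon would pull these parts apart, and whether the step carries over to the core of compound 1 remains open. Nothing in the data shown accounts for the step.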